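The compounds below may be only part of what the source reports. "The series", "measured", "known", "first", "only" and "open" are said of these compounds alone.

Measured in an ADME assay on Raji cells (Homo sapiens) for cytotoxicity, read by luminescence, with a stated time of 72 h; a lower number here means that less compound is needed, a higher number that more compound is needed for the effect:
- compound 1 `CCOC(=O)c1c(-c2cccc(C)c2)[nH]c2cc(OC)ccc2c1=O`: > 21500 nM (a limit)
- compound 2 `CCCCOc1cccc(-c2[nH]c3cc(OC)ccc3c(=O)c2C(=O)OCC)c1`: > 21500 nM (a limit)

Compound 2 gives no number in this assay: its > 21500 nM is a limit. Among the compounds with values here, the series so far consists of the limit of > 21500 nM in this assay, at which 2 of the 2 values shown sit, so compound 2 cannot be ranked against compound 1.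

The next compound is compound 3 `CCOC(=O)c1c(-c2cccc(C(F)(F)F)c2)[nH]c2cc(OC)ccc2c1=O`, which carries trifluoromethyl in place of butoxy on an aromatic carbon. Within the data shown here, the one measured step that bears on this change also falls on an aromatic carbon, with butoxy in place of methyl: a step that the two limits leave unreadable from compound 1 to compound 2. That step has no size to carry over. Methyl and butoxy both end at the same limit, so the data give no sign that a group at this place moves the read-out into a measurable range.

The expected step is a step that the limit leaves unreadable from compound 2 to compound 3, with no readable change and no direction expected. In this assay the estimate for compound 3 is 30000 nM, with an expected range of 12000 nM to 60000 nM, and a report as a limit is the most likely outcome.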

Compound 3, half-maximal effective concentration: > 21500 nM
Compound 3: a limit, no number; the forecaster's own chance of this, stated with the estimate: 85%; the middle value is on the limit's open side.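

Compound 3 ends as a limit in this assay, so no step among compound 1, compound 2 and compound 3 can be read, and the series stays at a single limit: the limit of > 21500 nM in this assay, at which 3 of the 3 values shown sit.

The compounds shown leave open whether any group at this place on the shared core gives a readable number, and how methyl, butoxy and trifluoromethyl rank against one another.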